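The source may hold more compounds than are shown below. What is called first, only, known or untested is meant among the compounds shown, and "the series" means these compounds.

In a physicochemical assay for solubility, read by LC-MS, using the shake flask method, measured as thermodynamic solubility, with a stated time of 24 h, at pH 6.5 (a lower number here means a less soluble compound, a higher number a more soluble compound), compound 1 `O=C(O)c1ccc(-n2cc(CO[C@H]3O[C@H](CO)[C@@H](O)[C@H](O)[C@@H]3O)nn2)cc1` gives only a limit, > 3000 ug/mL. Compound 2 `Nc1ccc(-n2cc(CO[C@H]3O[C@H](CO)[C@@H](O)[C@H](O)[C@@H]3O)nn2)cc1` likewise gives a limit, > 2000 ug/mL. Compound 3 `COc1ccc(Cn2cc(CO[C@H]3O[C@H](CO)[C@@H](O)[C@H](O)[C@@H]3O)nn2)cc1` also gives only a limit in this assay, > 3000 ug/mL. Of the three values shown, two sit at the limit of > 3000 ug/mL in this assay, at which 2 of the 3 values shown sit, and one at the limit of > 2000 ug/mL in this assay, at which 1 of the 3 values shown sits. Compound 4 `OC[C@H]1O[C@H](OCc2cn(-c3cccc(F)c3)nn2)[C@@H](O)[C@@H](O)[C@@H]1O` differs from compound 3 by 3-fluorophenyl in place of 4-methoxybenzyl on an aromatic nitrogen. Going by the values given here, the steps a step that the two limits leave unreadable from compound 1 to compound 3 and a step that the two limits leave unreadable from compound 2 to compound 3 both swap the group on the same aromatic nitrogen, and a step that the two limits leave unreadable from compound 1 to compound 2 is equally unreadable, so no measured step gives a size to expect. The step of an at least 1.2-fold lower number from compound 3 to compound 4 (0.07 log units; that floor lies within the scatter) is therefore expected to stay small, at most a slight loss. Compound 4 is estimated at 2500 ug/mL, between 800 ug/mL and 3000 ug/mL.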

Compound 4, solubility: > 3000 ug/mL
Compound 4 ended at the assay's limit (the forecaster's own chance of this, stated with the estimate: 55%); middle value at least 1.2-fold (0.07 log units) from the limit.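

Compound 4, like compound 1, compound 2 and compound 3, gives only a limit in this assay, so none of the steps to compound 4 can be read. From the compounds shown here alone, whether these four compounds truly differ at all stays open.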